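Shortening a Linker Chain in a Hydroxamic Acid Series

This account rests on a few compounds, and the source may have more. Where it says the series, first, only, none or still open, it means among the compounds named here.

Measured compounds:
- compound 1, `C#CCN(C)CCCOc1cc(NCc2ccc(/C=C/C(=O)NO)cc2)ccc1Cl`, 100 nM
- compound 2, `C#CCN(C)CCCOc1cc(NC(=O)CCCCCCCCC(=O)NO)ccc1Cl`, 160 nM

In an assay on isolated protein for inhibition of protein deacetylase HDAC6 (Homo sapiens), read by fluorescence (a lower number here means a stronger inhibitor, a higher number a weaker inhibitor), compound 1 gives 100 nM and compound 2 gives 160 nM. Compound 2 carries the higher of the two numbers, but the gap to compound 1 lies within the scatter of this assay, so the two are read as indistinguishable.

Compound 3, `C#CCN(C)CCCOc1cc(NC(=O)CCCCCCCC(=O)NO)ccc1Cl`, has not yet been measured. It differs from compound 2 in one place: hydroxycarbamoyl in place of (hydroxycarbamoyl)methyl on a saturated chain carbon, seven bonds along the chain from a carbonyl carbon. In plain words, the saturated chain that links the anilide carbonyl to the hydroxamic acid is one carbon shorter in compound 3 than in compound 2.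

Within the data shown here, no measured pair here shows what the loss of one chain carbon does, so the expected size of the step from compound 2 to compound 3 rests only on the two numbers in this assay. A small step, at most around the scatter and, if anything, toward a weaker inhibitor, is expected, with a 1.4-fold higher number from compound 2 to compound 3 (0.14 log units; within the scatter) as the estimated change. Compound 3 is therefore expected to give about 220 nM, within a range from 80 nM to 600 nM.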

Compound 3, half-maximal inhibitory concentration: 80 nM
Estimate against measurement, compound 3: 2.8-fold (0.44 log units) above; low and high end bracket the measured number.
By their numbers in this assay, from the lowest: compounds 3, 1 and 2 (each within the scatter of the next).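

In this assay, hydroxycarbamoyl in place of (hydroxycarbamoyl)methyl on a saturated chain carbon, seven bonds along the chain from a carbonyl carbon, gives a 2.0-fold lower number from compound 2 to compound 3 (0.30 log units; within the scatter). Among these compounds, this is the first direct reading of what one chain carbon is worth at this position, and it shows that the chain can lose that carbon with no change that can be told from the scatter, so compound 2 and compound 3 are read as indistinguishable in this measurement. Nothing measured alongside these numbers speaks to why the chain length makes so little difference here.

From the compounds shown here alone, a single step between two chain lengths fixes no trend, so it remains open what a chain shorter than that of compound 3, or a longer chain than that of compound 2, would do to the number in this assay. Also open, going by these compounds, is whether the same result would hold with a carboxylic acid in place of the hydroxamic acid, or with a different amine in place of the propargyl methyl amine on the shared core.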